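Trimethoxyphenyl in place of methoxybenzyl on a nitro-pyrimidine

The source may report more compounds than this note shows. Statements on the series, on what has been measured and on what is new or still open speak of the compounds shown alone.

Measured compounds:
compound 1, `CCOC(=O)CN(Cc1ccccc1)c1nc(NCc2cccc(OC)c2)ncc1[N+](=O)[O-]`: 33600 nM
compound 2, `CCOC(=O)CNc1nc(Nc2ccc(Cl)cc2)ncc1[N+](=O)[O-]`: > 100000 nM

The study measured antiproliferative activity in a functional assay on HepG2 cells (Homo sapiens) for antiproliferative activity, read by MTT assay, with a stated time of 48 h; a lower number here means a stronger inhibitor, a higher number a weaker inhibitor. Within the data shown here, compound 1 is the only compound to give a full number in this assay, where compound 1 reaches 33600 nM. Compound 2 is recorded only as a limit of this assay, and for compound 2 that limit is > 100000 nM, as the limit of > 100000 nM in this assay, at which 1 of the 2 values shown sits, states. Among the measured compounds shown here, no step between two measured compounds is available, so the size of any change must be judged on the structures alone.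

Compound 3, `CCOC(=O)CN(Cc1ccccc1)c1nc(Nc2cc(OC)c(OC)c(OC)c2)ncc1[N+](=O)[O-]`, has not yet been tested. Compound 3 differs from compound 1 by 3,4,5-trimethoxyphenyl in place of 3-methoxybenzyl on a nitrogen on an aromatic ring. For the measured compounds named here, with no measured step to lean on, the expected change is small, in either direction, and is not expected to go beyond the usual scatter of this assay. Compound 3 is therefore expected to sit near compound 1, at an estimated 30000 nM, within a range from 8000 nM to 100000 nM. That estimate means an expected step of a 1.1-fold lower number from compound 1 to compound 3 (0.05 log units; within the scatter).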

Compound 3, half-maximal inhibitory concentration: 37800 nM
Compound 3: the middle estimate sits 1.3-fold (0.10 log units) below what was measured; low and high end bracket the measured number.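

In this assay, putting 3,4,5-trimethoxyphenyl in place of 3-methoxybenzyl on a nitrogen on an aromatic ring gives a 1.1-fold higher number from compound 1 to compound 3 (0.05 log units; within the scatter). Among these compounds, this is the first step that can be read at this position, and it shows that the two groups cannot be told apart in this assay, even though the entering group carries 3 hydrogen-bond acceptors against 1 and 12 heavy atoms against 9. Compound 3 gives a full number, so compound 2 remains the only compound recorded as a limit, which is not a number and cannot be read as a step:  the limit of > 100000 nM in this assay, at which 1 of the 3 values shown sits.

What the compounds shown leave open is whether any group at this nitrogen can move the number beyond the scatter, for instance an aliphatic amine, a pyridine ring or a longer chain ending in a carboxylic acid. Among the compounds shown here, they also leave open how much the rest of the shared core contributes, since no step reports a change to the ethyl ester or the nitro group, such as a nitrile in place of the latter.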